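The compounds below may be only part of what the source reports. "The series", "measured", "known", "first", "only" and "open" are said of these compounds alone.

Measured so far: compound 1 `CCOC(=O)N1CCN(CCCOc2ccc(C(=O)c3ccc(OC)cc3)cc2)CC1` with 8320 nM in an assay on isolated protein for binding affinity to histamine H2 receptor (Homo sapiens); on this read-out lower numbers stand for stronger inhibition and higher numbers for weaker inhibition; compound 2 `CCOC(=O)N1CCN(CCCOc2ccc(C(=O)c3ccc(C(C)(C)C)cc3)cc2)CC1` with 1550 nM; compound 3 `CCOC(=O)N1CCN(CCCOc2ccc(C(=O)c3cccc(C)c3)cc2)CC1` with 3720 nM.

Compound 3 holds the second highest of the three numbers: a 2.2-fold lower number from compound 1 to compound 3 (0.35 log units; beyond the scatter) and a 2.4-fold higher number from compound 2 to compound 3 (0.38 log units; beyond the scatter). Compound 4 `CCOC(=O)N1CCN(CCCOc2ccc(C(=O)/C=C/c3ccc(OC)cc3)cc2)CC1` differs from compound 3 in that (2-(4-methoxyphenyl)ethenyl in place of 3-methylphenyl on a carbonyl carbon). Among the compounds with values here, only one measured step bears on this: a 2.2-fold lower number from compound 1 to compound 3 (0.35 log units; beyond the scatter) shows that the 4-methoxyphenyl ring went with the higher number, while nothing measured shows what the double bond contributes. A modest rise in the number, or none beyond the scatter, is therefore expected in this assay. Compound 4 is expected to give 5500 nM, within 1500 nM to 20000 nM, which means a 1.5-fold higher number from compound 3 to compound 4 (0.17 log units; within the scatter).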

Compound 4, inhibition constant: 6760 nM
Compound 4: middle estimate off by 1.2-fold (0.09 log units), on the low side; measured number inside the range.
By their numbers in this assay, from the lowest: compound 2; then compounds 3, 4 and 1 (each within the scatter of the next, the first and the last beyond it).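

In this assay, the step (a 1.2-fold lower number from compound 1 to compound 4 (0.09 log units; within the scatter)) shows that 2-(4-methoxyphenyl)ethenyl on the carbonyl carbon reads no differently from 4-methoxyphenyl, so adding the double bond moved the number by no more than the scatter. The step (a 1.8-fold higher number from compound 3 to compound 4 (0.26 log units; within the scatter)) likewise leaves it level with 3-methylphenyl, while 4-(tert-butyl)phenyl stays clearly apart (a 4.4-fold higher number from compound 2 to compound 4 (0.64 log units; beyond the scatter)). No evidence is available on why these groups read as they do.

Still open, from the compounds shown here alone, is whether 2-(4-(tert-butyl)phenyl)ethenyl would match compound 2, and how an amine or a carboxylic acid on the ring would read.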